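A few compounds are considered here, and "the series" means these few. Any claim that something is new, unique, unknown or untested is made for them only; others in the source may bear on it.

Measured compounds:
compound 1 `CC(C)C[C@H](NC(=O)[C@H](C)NC(=O)CC[C@H](NS(=O)(=O)c1ccc(Cl)c(C(F)(F)F)c1)C(=O)O)C(=O)N[C@@H](C)C(N)=O` — 1700 nM
compound 2 `O=C(O)[C@H](CCc1ccccc1)NS(=O)(=O)c1ccc(Cl)c(C(F)(F)F)c1` — 6100 nM
compound 3 `CC(C)C[C@H](NC(=O)CNC(=O)CC[C@H](NS(=O)(=O)c1ccc(Cl)c(C(F)(F)F)c1)C(=O)O)C(=O)N[C@H](C(N)=O)C(C)C` — 56 nM

In an assay on isolated protein for inhibition of Matrilysin (Homo sapiens), read by fluorescence, with a stated time of 15 min (on this read-out higher numbers stand for weaker inhibition and lower numbers for stronger inhibition), compound 3 gives the lowest of the three numbers. Compound 1 stands a good deal higher, and compound 2 higher still; both gaps are described as beyond the scatter, so compound 3 is the strongest inhibitor among the measured set.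

Compound 4 `CSCC[C@H](NC(=O)[C@H](CC(C)C)NC(=O)CNC(=O)CC[C@H](NS(=O)(=O)c1ccc(Cl)c(C(F)(F)F)c1)C(=O)O)C(N)=O` differs from compound 3 in one place:

2-(methylsulfanyl)ethyl in place of isopropyl on a saturated chain carbon bound to an amide-type nitrogen and a carbonyl carbon

Among the compounds with values here, no step between two measured compounds matches this change, so nothing measured tells directly how the exchange of one chain for another at this place moves the number in this assay. The peptide-like part of compound 3 is otherwise kept intact, and the part that carries the sulfonamide and the acid is unchanged. The step from compound 3 to compound 4 is therefore expected to be small, most likely within the scatter, a 1.3-fold higher number from compound 3 to compound 4 (0.10 log units; within the scatter). Compound 4 is estimated to give 70 nM, with a range from 20 nM to 250 nM.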

Compound 4, half-maximal inhibitory concentration: 120 nM
For compound 4 the middle estimate is 1.7-fold (0.23 log units) below the measured one; low and high end bracket the measured number.
By their numbers in this assay, from the lowest: compound 3; then compound 4; then compound 1; then compound 2.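

In this assay, 2-(methylsulfanyl)ethyl in place of isopropyl on a saturated chain carbon bound to an amide-type nitrogen and a carbonyl carbon gives a 2.1-fold higher number from compound 3 to compound 4 (0.33 log units; beyond the scatter) as a modest step. Within the data shown here, no earlier pair of compounds differed in one place, so this is the first direct reading of any change at this position. It shows that the isopropyl can be exchanged for this sulfur-bearing chain with a move towards weaker inhibition that remains small in size. No supporting measurement bears on what lies behind this step. Going by these compounds, whether the shift goes with the sulfur atom or with the chain length stays open, and a butyl chain at this place would bear on that. On these data alone, how a chain ending in an amine or a carboxylic acid would read here is also open.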